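Capping the amine of compound 2

This account rests on a few compounds, and the source may have more. Where it says the series, first, only, none or still open, it means among the compounds named here.

Compound 1 `CCCCCCCCCCCCCC(=O)NC(CO[C@@H]1O[C@H](CO)[C@H](O)[C@H](O)[C@H]1O)C(=O)NCCOS(=O)(=O)O` gives > 100000 nM
Compound 2 `NC(CO[C@@H]1O[C@H](CO)[C@H](O)[C@H](O)[C@H]1O)C(=O)NCCCCCCCCCCCC(=O)O` gives > 100000 nM
Compound 3 `CCCCCCCCCCCCCCNC(=O)C(CO[C@@H]1O[C@H](CO)[C@H](O)[C@H](O)[C@H]1O)NC(=O)CCCCCCCCCCC(=O)O` gives > 100000 nM

In a functional assay on MT4 cells (Homo sapiens) for cytotoxicity (on this read-out higher numbers stand for lower toxicity in this test and lower numbers for higher toxicity in this test), compound 2 gives > 100000 nM as a limit and not a number. All three measured compounds share this reading (the limit of > 100000 nM in this assay, at which 3 of the 3 values shown sit). Compound 4 `O=C(O)CCCCCCCCCCCNC(=O)C(CO[C@@H]1O[C@H](CO)[C@H](O)[C@H](O)[C@H]1O)NC(=O)CCC(=O)O` still awaits measurement. It differs from compound 2 by (2-carboxyethyl)carbonyl in place of hydrogen on an amine nitrogen with (2-carboxyethyl)carbonyl in place of hydrogen on an amine nitrogen. For the measured compounds named here, no measured pair shows a change of this kind. For compound 4 the expectation therefore rests on compound 2 at > 100000 nM and on the shared reading (the limit of > 100000 nM in this assay, at which 3 of the 3 values shown sit). In this assay the expected step is a number no higher from compound 2 to compound 4 (the limit leaves the size open) and none beyond the scatter in either direction. For compound 4 the estimated value is 100000 nM with an expected range (40000 nM to 200000 nM).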

Compound 4, half-maximal cytotoxic concentration: > 100000 nM
Compound 4: no number, only a limit; the forecaster's own chance of this, stated with the estimate: 85%; the middle value lies on the limit itself.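

In this assay, compound 2 and compound 4 each give only a limit and not a number, and the step between them cannot be read. The compounds shown leave open what (2-carboxyethyl)carbonyl in place of hydrogen on the amine nitrogen does to this read-out.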